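Swapping the Aryl Urea End: From Nitro to Chloro-Trifluoromethyl

This account rests on a few compounds, and the source may have more. Where it says the series, first, only, none or still open, it means among the compounds named here.

Two diaryl ureas built on one shared core have been measured in a functional assay on MDA-MB-231 cells (Homo sapiens) for cytotoxicity, read by MTT assay, with a stated time of 48 h; a higher number here means a weaker inhibitor, a lower number a stronger inhibitor. Compound 1 `O=C(NCCCCC(c1ccc(F)cc1)c1ccc(F)cc1)Nc1ccc(Cl)cc1` gives 7680 nM. Compound 2 `O=C(NCCCCC(c1ccc(F)cc1)c1ccc(F)cc1)Nc1cccc([N+](=O)[O-])c1` gives 3790 nM, the lowest of the two numbers, so compound 2 is the stronger of the pair: a 2.0-fold lower number from compound 1 to compound 2 (0.31 log units; beyond the scatter). For the measured compounds named here, the next member, compound 3 `O=C(NCCCCC(c1ccc(F)cc1)c1ccc(F)cc1)Nc1ccc(Cl)cc1C(F)(F)F`, has not yet been measured. 4-chloro-2-(trifluoromethyl)phenyl in place of 3-nitrophenyl on an amide-type nitrogen The single measured step is the only guide here, and it moved the number only modestly. Going by the values given here, the entering group carries the same 4-chloro found in compound 1 together with a trifluoromethyl that no measured compound holds, so the data give no direct precedent for it. The expectation for compound 3 is therefore a step back toward the number of compound 1, estimated as a 1.5-fold higher number from compound 2 to compound 3 (0.16 log units; within the scatter). Compound 3 is expected to give about 5500 nM in this assay, with a plausible range from 2000 nM to 15000 nM.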

Compound 3, half-maximal inhibitory concentration: > 20000 nM
Compound 3 was reported as a limit (the forecaster's own chance of this, stated with the estimate: 5%); middle value at least 3.6-fold (0.56 log units) from the limit.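

Compound 3 is reported in this assay only as a limit of the assay and not as a number: the limit of > 20000 nM in this assay, at which 1 of the 3 values shown sits. Putting trifluoromethyl in place of hydrogen on an aromatic carbon gives an at least 2.6-fold higher number from compound 1 to compound 3 (0.41 log units; beyond the scatter), so this single added group changes the number in the opposite direction from the earlier step. Exchanging the aryl end on the amide-type nitrogen gives an at least 5.2-fold higher number from compound 2 to compound 3 (0.72 log units; beyond the scatter), which shows that this place can shift the number much further than the first pair suggested.

Going by these compounds, how far compound 3 lies past its limit stays unknown, so both steps have only a lower bound. On these data alone, whether a methyl or a methoxy in place of the trifluoromethyl would leave the number nearer to that of compound 1 also stays open.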